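The compounds below may be only part of what the source reports. "The series", "measured", "known", "first", "only" and "open" are said of these compounds alone.

Series notes. Compound 1 `Cc1ccc(CNC(=O)C(C)Oc2ccc(Cl)cc2Cl)cc1` in an ADME assay on CHO cells (Cricetulus griseus) for cytotoxicity, read by LDH release (a higher number here means a weaker inhibitor, a lower number a stronger inhibitor), gives 25000 nM. Compound 2 `Cc1cccc(CNC(=O)C(C)Oc2ccc(Cl)cc2Cl)c1` in this assay gives 45000 nM; the two cores differ by 3-methylphenyl in place of 4-methylphenyl on a saturated chain carbon bound to an amide-type nitrogen, and the step of a 1.8-fold higher number from compound 1 to compound 2 (0.26 log units; within the scatter). Compound 3 `COc1ccc(CNC(=O)C(C)Oc2ccc(Cl)cc2Cl)cc1` in this assay gives 71000 nM, a step of a 2.8-fold higher number from compound 1 to compound 3 (0.45 log units; beyond the scatter) for the change (methoxy in place of methyl on an aromatic carbon). Compound 4 `COc1cccc(CNC(=O)C(C)Oc2ccc(Cl)cc2Cl)c1` has no number yet in this assay; it differs from compound 2 by methoxy in place of methyl on an aromatic carbon. This is the same kind of change as the one measured before, but the place is not identical: para to a large group earlier, meta to a large group here. Among the compounds with values here, compound 4 is expected to show a 2.2-fold higher number from compound 2 to compound 4 (0.35 log units; beyond the scatter), an estimate resting on the single earlier instance a 2.8-fold higher number from compound 1 to compound 3 (0.45 log units; beyond the scatter) and on the value of compound 2, with the shifted place adding uncertainty. Compound 4 is thus estimated at 100000 nM in this assay, with a likely range from 40000 nM to 250000 nM.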

Compound 4, half-maximal inhibitory concentration: > 100000 nM
Compound 4 ended at the assay's limit (the forecaster's own chance of this, stated with the estimate: 20%); the middle value lies on the limit itself.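

Compound 4 gives > 100000 nM in this assay, which is a limit of the assay and not a number. Methoxy in place of methyl still gives a readable step, an at least 2.2-fold higher number from compound 2 to compound 4 (0.34 log units; beyond the scatter), so on these two cores the change goes the same way, with the higher number carrying over from the core of compound 1 to the core of compound 2. This does not show that the size of the step carries over: the same change on two cores in this assay, a 2.8-fold higher number (0.45 log units; beyond the scatter) from compound 1 to compound 3 and an at least 2.2-fold higher number (0.34 log units; beyond the scatter) from compound 2 to compound 4; the limit leaves it open whether they differ

From the compounds shown here alone, it remains open how a nitrile, an amine or a carboxylic acid would read at the same place on the aromatic ring. With only two cores shown, it also remains open whether the change goes the same way on a core with a longer chain.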